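The source may report more compounds than this note shows. Statements on the series, on what has been measured and on what is new or still open speak of the compounds shown alone.

Measured compounds:
Compound 1 `CC(C)CSc1n[nH]c(-n2[se]c3ccccc3c2=O)n1` gives 34900 nM in a functional assay on HeLa cells (Homo sapiens) for antiproliferative activity, read by CCK-8 assay, with a stated time of 48 h; on this read-out lower numbers stand for stronger inhibition and higher numbers for weaker inhibition.
Compound 2 `Cc1cccc(CSc2n[nH]c(-n3[se]c4ccccc4c3=O)n2)c1` gives 42600 nM in this assay.

Within the data shown here, compound 2 holds the higher of the two numbers in this assay, and its only neighbour is compound 1, whose number lies within the scatter of it. Among the measured compounds shown here, the single measured step, a 1.2-fold higher number from compound 1 to compound 2 (0.09 log units; within the scatter), thus shows no difference that can be trusted. Compound 3 `O=c1c2ccccc2[se]n1-c1nc(SCc2ccc(Cl)cc2)n[nH]1` has not yet been measured. It differs from compound 2 by 4-chlorophenyl in place of 3-methylphenyl on a saturated chain carbon bound to a sulfur. For the measured compounds named here, only that one step bears on this change: it put an aromatic ring in place of isopropyl on the saturated chain carbon bound to a sulfur and moved the number only within the scatter, whereas the present change keeps one six-membered aromatic ring of carbon only at that place and exchanges 3-methylphenyl for 4-chlorophenyl. Going by the values given here, no measured compound carries a chlorine there, so the direction cannot be read from the data. The step expected for a 1.1-fold lower number from compound 2 to compound 3 (0.03 log units; within the scatter) is therefore none beyond the scatter. Compound 3 is estimated at 40000 nM, with a range from 15000 nM to 100000 nM.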

Compound 3, half-maximal inhibitory concentration: 40900 nM
Estimate against measurement, compound 3: 1.0-fold (0.01 log units) below; the range from low to high includes it.
By their numbers in this assay, from the lowest: compounds 1, 3 and 2 (each within the scatter of the next).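

Among these compounds, with compound 3, a chlorine appears for the first time at the place on a saturated chain carbon bound to a sulfur, and in this assay the exchange of 3-methylphenyl for 4-chlorophenyl gives a 1.0-fold lower number from compound 2 to compound 3 (0.02 log units; within the scatter) while the exchange of isopropyl for 4-chlorophenyl gives a 1.2-fold higher number from compound 1 to compound 3 (0.07 log units; within the scatter) and both steps lie within the scatter. Across the three compounds, then, isopropyl, 3-methylphenyl and 4-chlorophenyl cannot be told apart at this place, and neither the kind of substituent on the aromatic ring nor its presence separates any one compound from the others. Nothing measured alongside these numbers offers an account of why the three groups read alike.

Still open, as far as these compounds go, is whether any group at this place gives a number beyond the scatter, for instance a 3-chlorophenyl, a phenyl carrying an amine or a carboxylic acid, or a longer chain in place of isopropyl. Open too, from the compounds shown here alone, is what a change to the shared core would do, since all three compounds carry it unchanged.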